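Replacing an Isopropyl Group with a Second Aromatic Ring

The compounds below may be only part of what the source reports. "The series", "measured", "known", "first", "only" and "open" are said of these compounds alone.

Compound 2, `Cc1cc(C(C)C)nnc1N1CCN(c2ncccn2)CC1`, is one of three compounds tested in a functional assay on BV-2 cells (Mus musculus) for inhibition, read by ELISA, with a stated time of 16 h; a lower number here means a stronger inhibitor, a higher number a weaker inhibitor. In this assay compound 2 reaches only the limit of > 100000 nM, so no number is known for it. Compound 1, `Cc1cc(Cl)nnc1N1CCN(c2ncccn2)CC1`, sits at the same limit, giving > 100000 nM. Compound 3, `COc1cccc(-c2cc(C)c(N3CCN(c4ncccn4)CC3)nn2)c1`, gives 2600 nM. Among the measured compounds shown here, the step that the two limits leave unreadable from compound 1 to compound 2 shows only that neither compound yields a number, as noted in the limit of > 100000 nM in this assay, at which 2 of the 3 values shown sit. Both an at least 38-fold lower number from compound 1 to compound 3 (1.58 log units; beyond the scatter) and an at least 38-fold lower number from compound 2 to compound 3 (1.58 log units; beyond the scatter) show a large gain when an aromatic ring enters at this carbon. Compound 4, `Cc1cc(-c2cncnc2)nnc1N1CCN(c2ncccn2)CC1`, makes a related change: pyrimidin-5-yl in place of isopropyl on an aromatic carbon. Pyrimidin-5-yl is also a six-membered aromatic ring, so the large step of an at least 38-fold lower number from compound 2 to compound 3 (1.58 log units; beyond the scatter) bears on it directly. A somewhat smaller gain is expected, with the step of an at least 12-fold lower number from compound 2 to compound 4 (1.09 log units; beyond the scatter) estimated. Compound 4 is expected to give about 8000 nM, between 1500 nM and 60000 nM.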

Compound 4, half-maximal inhibitory concentration: > 100000 nM
Compound 4 gave a limit, no number; the forecaster's own chance of this, stated with the estimate: 20%; middle value at least 12-fold (1.09 log units) away from the limit.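

In this assay, a six-membered aromatic ring at this carbon does not by itself bring the gain, as pyrimidin-5-yl in place of 3-methoxyphenyl gives an at least 38-fold higher number from compound 3 to compound 4 (1.58 log units; beyond the scatter). Compound 4 joins the compounds that give only a limit and no number: the limit of > 100000 nM in this assay, at which 3 of the 4 values shown sit. The steps from compound 1 and from compound 2 to compound 4 cannot be read. Still open, as far as these compounds go, is whether plain phenyl, without the methoxy group, would keep the activity of compound 3. From the compounds shown here alone, it is also open whether the methoxy group matters at this ring carbon, which 3-hydroxyphenyl or 4-methoxyphenyl could test.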